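Piperidine versus piperazine amides on a shared pyrazole core

The compounds below may be only part of what the source reports. "The series", "measured", "known", "first", "only" and "open" are said of these compounds alone.

Measured compounds:
- compound 1 `CC1(C)c2[nH]nc(NC(=O)c3ccc(F)cc3)c2CN1C(=O)C1CCN(C2CC2)CC1`: 380 nM
- compound 2 `CC(=O)N1CCN(C(=O)N2Cc3c(NC(=O)c4ccc(F)cc4)n[nH]c3C2(C)C)CC1`: > 10000 nM
- compound 3 `CN1CCC(C(=O)N2Cc3c(NC(=O)c4ccc(Cl)cc4)n[nH]c3C2(C)C)CC1`: 120 nM

All three share the same core and differ at the group attached to the carbonyl carbon of the ring amide, and in the halogen on the benzamide. In a functional assay on A2780 cells (Homo sapiens) for antiproliferative activity, read by fluorescence, with a stated time of 72 h (a lower number here means a stronger inhibitor, a higher number a weaker inhibitor), compound 1 gives 380 nM and compound 3 gives 120 nM. For compound 2 this assay reports only a limit, > 10000 nM, so it sits at the weak end of the values shown (the limit of > 10000 nM in this assay, at which 1 of the 3 values shown sits).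

Compound 4 `CC(=O)N1CCC(C(=O)N2Cc3c(NC(=O)c4ccc(F)cc4)n[nH]c3C2(C)C)CC1` has not yet been measured. It differs from compound 2 in one place: 1-acetylpiperidin-4-yl in place of 4-acetylpiperazin-1-yl on a carbonyl carbon. The new group keeps the acetyl of compound 2 but carries the piperidin-4-yl attachment of compound 1 and compound 3.

Among the compounds with values here, only one measured step bears on this change: an at least 26-fold higher number from compound 1 to compound 2 (1.42 log units; beyond the scatter). That step swapped the whole group at once, from 1-cyclopropylpiperidin-4-yl to 4-acetylpiperazin-1-yl, so it does not show how much of the loss comes from the acetyl and how much from the ring attachment. Compound 4 sits between those two cases, and the expected step of an at least 1.6-fold lower number from compound 2 to compound 4 (0.22 log units; that floor lies within the scatter) is therefore a gain of uncertain size from a limit. For compound 4 the estimate in this assay is 6000 nM, within 1200 nM to 30000 nM.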

Compound 4, half-maximal inhibitory concentration: > 10000 nM
Compound 4 gave a limit, no number; the forecaster's own chance of this, stated with the estimate: 35%; middle value at least 1.6-fold (0.22 log units) from the limit.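

Within the data shown here, only one thing changes here, acetyl in place of cyclopropyl on an amine nitrogen in a ring, with the piperidin-4-yl attachment kept, and this gives an at least 26-fold higher number from compound 1 to compound 4 (1.42 log units; beyond the scatter) in this assay. The earlier step changed the whole group at once, whereas this one shows that the acetyl swap alone is enough for a large loss. Compound 4 gives only a limit, so the piperidin-4-yl attachment does not restore a readable value when the ring nitrogen carries acetyl, and the step from compound 2 cannot be read, leaving the two acetyl compounds together at the weak end: the limit of > 10000 nM in this assay, at which 2 of the 4 values shown sit.

As far as these compounds go, the piperazine ring's own contribution remains open, and a 4-cyclopropylpiperazin-1-yl group, set against compound 1, would test it in a single change. From the compounds shown here alone, it is also open how other groups on the piperidine nitrogen would read, such as ethyl, a longer alkyl chain or a plain hydrogen, and whether any acetyl-like carbonyl group on that nitrogen can give a value short of the limit.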